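Benzyl in place of methylphenyl in a cytotoxicity series

The source may hold more compounds than are shown below. What is called first, only, known or untested is meant among the compounds shown, and "the series" means these compounds.

Compound 1 `CCN1CCN(CCCSc2nnc(-c3ccc(C)cc3)[nH]2)CC1` reaches only a limit of > 300000 nM in a functional assay on MCF7 cells (Homo sapiens) for cytotoxicity, read by MTT assay, with a stated time of 24 h; a higher number here means a weaker inhibitor, a lower number a stronger inhibitor.
Compound 2 `Cc1cccc(-c2nnc(SCCCN3CCN(c4ccccc4)CC3)[nH]2)c1` likewise stops at a limit of > 300000 nM in this assay.
Compound 3 `Cc1cccc(-c2nnc(SCCCN3CCN(c4ccccn4)CC3)[nH]2)c1` also gives no number, only a limit of > 300000 nM in this assay.

Compound 3 therefore stands at the upper boundary of what this assay can report: the limit of > 300000 nM in this assay, at which 3 of the 3 values shown sit. Going by the values given here, no compound in the set has a readable number, so compound 3 is neither stronger nor weaker than any other here. Among the compounds with values here, the single measured step, a step that the two limits leave unreadable from compound 2 to compound 3, changes the group on the ring amine nitrogen, not the part of the core altered next, and its size cannot be read because both ends sit at the limit.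

Compound 4 `c1ccc(Cc2nnc(SCCCN3CCN(c4ccccn4)CC3)[nH]2)cc1` differs from compound 3 by benzyl in place of 3-methylphenyl on an aromatic carbon. Within the data shown here, no measured step touches this position, so there is nothing to say how large an effect this change should have, in either direction. Given that every measured value sits at the limit, the expectation for compound 4 is that it too will most likely return a limit rather than a number, with a step of a number no higher from compound 3 to compound 4 (the limit leaves the size open) expected from compound 3 to compound 4. Compound 4 is estimated at 300000 nM, in the range 80000 nM to 1000000 nM.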

Compound 4, half-maximal inhibitory concentration: > 300000 nM
Compound 4: no number, only a limit (the forecaster's own chance of this, stated with the estimate: 80%); the middle value lies on the limit itself.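

Compound 3 and compound 4 both give only a limit rather than a number, so the size of the change between them cannot be read, and the same holds for the whole set: the limit of > 300000 nM in this assay, at which 4 of the 4 values shown sit. The compounds shown leave open how strong any of them truly is in this assay, and whether benzyl or 3-methylphenyl matters at this place.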